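Trifluoromethyl Added to the Aniline of Compound 2

This account rests on a few compounds, and the source may have more. Where it says the series, first, only, none or still open, it means among the compounds named here.

Compound 1 `Brc1ccc2ncnc(Nc3ccccc3)c2c1`: > 10000 nM
Compound 2 `Fc1ccc2ncnc(Nc3ccccc3)c2c1`: > 10000 nM

In a functional assay on HEK293 cells for antagonist activity at metabotropic glutamate receptor 5 (Rattus norvegicus), read by calcium flux (on this read-out lower numbers stand for stronger inhibition and higher numbers for weaker inhibition), compound 2 gives only > 10000 nM, a limit of the assay, not a number. Compound 1 likewise sits at a limit, > 10000 nM, so the step that the two limits leave unreadable from compound 1 to compound 2 cannot be read, and both values rest at the limit of > 10000 nM in this assay, at which 2 of the 2 values shown sit. Compound 3 `Fc1ccc2ncnc(Nc3cccc(C(F)(F)F)c3)c2c1` differs from compound 2 by trifluoromethyl in place of hydrogen on an aromatic carbon. Within the data shown here, no measured step bears on this change, so its size in this assay is unknown. Compound 3 is nonetheless expected at 3000 nM, between 300 nM and 20000 nM. That estimate means a step of an at least 3.3-fold lower number from compound 2 to compound 3 (0.52 log units; beyond the scatter), and it may again end at a limit.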

Compound 3, half-maximal inhibitory concentration: > 10000 nM
Compound 3: only a limit was reported; the forecaster's own chance of this, stated with the estimate: 40%; middle value at least 3.3-fold (0.52 log units) from the limit.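

In this assay compound 3 gives > 10000 nM, a limit and not a number, so no step from compound 2 to compound 3 can be read: the limit of > 10000 nM in this assay, at which 3 of the 3 values shown sit.

The compounds shown leave open how strongly, if at all, any of them inhibits, and what trifluoromethyl in place of hydrogen changes.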